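The source may report more compounds than this note shows. Statements on the series, on what has been measured and on what is new or still open speak of the compounds shown alone.

Compound 1 `CCOC(=O)/C=C/c1ccncc1-c1ccc2c(cnn2C)c1` and compound 2 `CCOC(=O)/C=C/c1ccncc1-c1ccc2ccccc2c1` share the ethyl ester end but carry different cores; the difference between the two cores is not broken down here. In a functional assay on A549 cells (Homo sapiens) for inhibition, read by sulforhodamine B assay, with a stated time of 72 h (a higher number here means a weaker inhibitor of growth, a lower number a stronger inhibitor of growth), compound 1 gives 5030 nM, and in this assay compound 2 gives 5380 nM, the two values lying within the usual scatter of each other.

Compound 3 `O=C(O)/C=C/c1ccncc1-c1ccc2ccccc2c1` keeps the core of compound 2 and differs from it by one change (hydrogen in place of ethyl on an oxygen next to a carbonyl group). For compound 3 this assay reports only a limit, > 10000 nM, so the value is a bound rather than a number (the limit of > 10000 nM in this assay, at which 1 of the 3 values shown sits). The step from the ester to the acid on this core is an at least 1.8-fold higher number from compound 2 to compound 3 (0.26 log units; that floor lies within the scatter).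

Among the measured compounds shown here, compound 4 `Cn1ncc2cc(-c3cnccc3/C=C/C(=O)O)ccc21` is the corresponding acid on the core of compound 1, and the change from compound 1 to compound 4 hydrogen in place of ethyl on an oxygen next to a carbonyl group is the same kind of change as the one from compound 2 to compound 3, at the same place. Compound 4 has not yet been measured in this assay. Since the same change on the other core gave a weaker inhibitor of growth, as the step of an at least 1.8-fold higher number from compound 2 to compound 3 (0.26 log units; that floor lies within the scatter) shows, compound 4 is expected to give a higher number than compound 1, with an estimated step of a 3.0-fold higher number from compound 1 to compound 4 (0.47 log units; beyond the scatter). Compound 4 is therefore estimated at about 15000 nM, within a range from 6000 nM to 50000 nM, and it is likely that this assay will again report only a limit for compound 4.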

Compound 4, concentration for 50% growth inhibition: > 10000 nM
Compound 4 gave a limit, no number; the forecaster's own chance of this, stated with the estimate: 70%; the middle value lies beyond the limit too.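

In this assay compound 4 gives > 10000 nM, which is a limit of the assay and not a number, and it now stands with the other acid at that limit: the limit of > 10000 nM in this assay, at which 2 of the 4 values shown sit. Replacing ethyl with hydrogen on the oxygen next to the carbonyl group on this core can therefore be read only as a floor, an at least 1.9-fold higher number from compound 1 to compound 4 (0.29 log units; that floor lies within the scatter). On both cores, the acid fails to give a number where the ethyl ester does, so the change points the same way in these two pairs, but neither floor establishes a change beyond the scatter, and the data do not show whether the size of the step carries over from one core to the other: the same change on two cores in this assay, an at least 1.8-fold higher number (0.26 log units; that floor lies within the scatter) from compound 2 to compound 3 and an at least 1.9-fold higher number (0.29 log units; that floor lies within the scatter) from compound 1 to compound 4; the limit leaves it open whether they differ.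

The compounds shown leave open how a methyl ester, a primary amide or an ester with a longer chain in place of the ethyl ester would read on either core. Among the compounds shown here, they also leave open whether the carbon-carbon double bond of the 2-(ethoxycarbonyl)ethenyl group matters, as no compound here carries a saturated chain in its place.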